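A step from methoxyphenyl to fluorophenyl on the shared core

The source may report more compounds than this note shows. Statements on the series, on what has been measured and on what is new or still open speak of the compounds shown alone.

Compound 2 `COc1ccc(-c2cn3ccnc3c(-c3ccc4ncn(C5CCCCC5)c4c3)n2)cc1` stands highest of the two numbers measured: in a functional assay on SR cells (Homo sapiens) for inhibition, read by sulforhodamine B assay, with a stated time of 48 h, tested at 10 uM (on this read-out higher numbers stand for more inhibition at the one concentration tested (going by the name of the read-out) and lower numbers for less inhibition), compound 2 gives 91.7%, while compound 1 `Brc1cn2ccnc2c(-c2ccc3ncn(C4CCCCC4)c3c2)n1` gives 26.8% in this assay. Within the data shown here, the only measured step, a number 64.9 percentage points higher from compound 1 to compound 2 (beyond the scatter), is large and beyond the scatter.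

Compound 3 `Fc1ccccc1-c1cn2ccnc2c(-c2ccc3ncn(C4CCCCC4)c3c2)n1` differs from compound 2 in one place: 2-fluorophenyl in place of 4-methoxyphenyl on an aromatic carbon. Among the measured compounds shown here, no measured pair shows this exchange directly. The step from compound 1 to compound 2 bears on it only loosely, since it shows that an aryl group at this place is compatible with strong inhibition, whereas compound 3 keeps an aryl group and changes only its substituent. A modest fall, perhaps within or just beyond the scatter, is therefore expected rather than a return toward compound 1.

Compound 3 is estimated at 75%, within 45% to 95%, an expected step of a number 16.7 percentage points lower from compound 2 to compound 3 (beyond the scatter).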

Compound 3, a percentage reported as inhibition, at one concentration (the size of the read-out at that concentration, not a potency): 16.3%
The estimate for compound 3 lay 58.7 percentage points above the measured number, outside the stated range (below it).
By their numbers in this assay, from the lowest: compound 3; then compound 1; then compound 2.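

In this assay, an aryl group at this aromatic carbon is not enough on its own for strong inhibition: 2-fluorophenyl in place of 4-methoxyphenyl gives a number 75.4 percentage points lower from compound 2 to compound 3 (beyond the scatter), even though both groups hold one six-membered aromatic ring of carbon only. Set against bromo, 2-fluorophenyl gives a number 10.5 percentage points lower from compound 1 to compound 3 (beyond the scatter), so the large gain seen earlier belongs to 4-methoxyphenyl and does not extend to every aryl group at this place. No measurement available here accounts for the difference between these two aryl groups.

The exchange alters both the substituent and where it stands on the phenyl ring, and the compounds shown do not separate these two changes. On these data alone, it also remains open how a plain phenyl group, or a phenyl ring carrying an amine or a carboxylic acid, would behave at this position.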